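This account rests on a few compounds, and the source may have more. Where it says the series, first, only, none or still open, it means among the compounds named here.

Compound 1 `CCCNc1cc(Oc2ccc(NC(=O)Nc3cccc(C(F)(F)F)c3)cc2)ncn1`: 32 nM
Compound 2 `CNc1cc(Oc2ccc(NC(=O)Nc3cccc(CF)c3)cc2)ncn1`: 400 nM

Of the two compounds measured in an assay on isolated protein for inhibition of serine/threonine-protein kinase TNNI3K (Homo sapiens) (on this read-out lower numbers stand for stronger inhibition and higher numbers for weaker inhibition), compound 2 gives the higher number, 400 nM, while compound 1 gives 32 nM, a gap well beyond the scatter. Compound 3 `CNc1cc(Oc2ccc(NC(=O)Nc3cccc(C(F)F)c3)cc2)ncn1` differs from compound 2 in one place: fluoro in place of hydrogen on a saturated chain carbon bound to an aromatic carbon and a fluorine atom. Since compound 1, which carries a trifluoromethyl, gives 32 nM, a step toward stronger inhibition is expected here. The step from compound 2 to compound 3 is estimated at a 2.7-fold lower number from compound 2 to compound 3 (0.43 log units; beyond the scatter). Compound 3 is therefore expected to give about 150 nM, within a range of 50 nM to 400 nM.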

Compound 3, half-maximal inhibitory concentration: 100 nM
The estimate for compound 3 lay 1.5-fold (0.18 log units) above the measured number, within the range that was stated.
By their numbers in this assay, from the lowest: compound 1; then compound 3; then compound 2.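

In this assay, fluoro in place of hydrogen on this saturated chain carbon, turning fluoromethyl into difluoromethyl, gives a 4.0-fold lower number from compound 2 to compound 3 (0.60 log units; beyond the scatter) and so shows that this position responds to a single added fluorine. Compounds 1 and 2 could not show this, as they differ in more than one place. Nothing available accounts for the size of this step.

On these data alone, compound 1 also differs from compound 3 in more than one place, so the effect of a third fluorine on this carbon remains open. Also open, as far as these compounds go, is how a nitrile or a methoxy group would fare at this place.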